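Side-chain change from compound 1 to compound 4

The compounds below may be only part of what the source reports. "The series", "measured", "known", "first", "only" and "open" are said of these compounds alone.

compound 1 `CCn1c(C(=O)NCCCN(C)C)ccc1C(CC)(CC)c1ccc(OCC(=O)C(C)(C)C)c(C)c1`: 1600 nM
compound 2 `CCn1c(C(=O)NCCCN(C)C)ccc1C(CC)(CC)c1ccc(OCC(O)C(C)(C)C)c(C)c1`: 3100 nM
compound 3 `CCn1c(C(=O)NCCN)ccc1C(CC)(CC)c1ccc(OCC(O)C(C)(C)C)c(C)c1`: 940 nM

In a functional assay on PC-3 cells (Homo sapiens), read by MTT assay, with a stated time of 48 h (on this read-out higher numbers stand for weaker inhibition and lower numbers for stronger inhibition), compound 1 stands within the scatter of both other measured compounds, and only those two lie beyond the scatter of each other.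

Compound 4 `CCn1c(C(=O)N(C)CC(=O)O)ccc1C(CC)(CC)c1ccc(OCC(=O)C(C)(C)C)c(C)c1` keeps the core of compound 1 and its (tert-butyl)carbonyl group. The change is (carboxymethyl)(methyl)amino in place of (3-(dimethylamino)propyl)amino on a carbonyl carbon. In words, (carboxymethyl)(methyl)amino takes the place of (3-(dimethylamino)propyl)amino on a carbonyl carbon.

Two measured steps are available. The step of a 1.9-fold higher number from compound 1 to compound 2 (0.29 log units; within the scatter) alters the (tert-butyl)carbonyl group, which compound 4 retains, so it bears little on this change. The step of a 3.3-fold lower number from compound 2 to compound 3 (0.52 log units; beyond the scatter) alters the same amide side chain and is modest, which makes it the closer guide. It replaces far less of the chain than the change to compound 4 does.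

Among the compounds with values here, no measured compound carries the carboxymethyl group, so the data do not fix the direction, and the expectation of a higher number in this assay is a judgement with a wide range. The expected step is a 2.8-fold higher number from compound 1 to compound 4 (0.45 log units; beyond the scatter).

For compound 4 the estimate is 4500 nM, with an expected range of 1500 nM to 14000 nM.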

Compound 4, half-maximal inhibitory concentration: 18400 nM
Compound 4: the middle estimate sits 4.1-fold (0.61 log units) below what was measured; measured number above the stated range.
By their numbers in this assay, from the lowest: compounds 3, 1 and 2 (each within the scatter of the next, the first and the last beyond it); then compound 4.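

In this assay, within the data shown here, the side chain on the carbonyl carbon carries much more weight than the earlier compounds showed: a 12-fold higher number from compound 1 to compound 4 (1.06 log units; beyond the scatter) is a large step, with (carboxymethyl)(methyl)amino in place of (3-(dimethylamino)propyl)amino. The earlier change to this side chain, a 3.3-fold lower number from compound 2 to compound 3 (0.52 log units; beyond the scatter) on the background carrying 1-hydroxy-2,2-dimethylpropyl, ran in the opposite direction and was only modest, so changes here can move the number either way in this series. Nothing measured here accounts for the large step.

The change to compound 4 removes the dimethylamino end, brings in a carboxylic acid and puts a methyl on the amide nitrogen all at once, and the compounds shown do not separate how much of the step belongs to each of these. A (carboxymethyl)amino group on the same carbonyl carbon, a (3-carboxypropyl)amino group with its longer chain, or a methyl ester in place of the carboxylic acid would each bear on that question, as would the same side chain on the 1-hydroxy-2,2-dimethylpropyl background.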